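A methylpiperazine added to the propyl chain of compound 3

The source may hold more compounds than are shown below. What is called first, only, known or untested is meant among the compounds shown, and "the series" means these compounds.

Measured in an ADME assay on HEK293 cells (Homo sapiens) for cytotoxicity, read by MTT assay, with a stated time of 48 h; a higher number here means a weaker inhibitor, a lower number a stronger inhibitor:
Compound 1 `Cn1c(N)c(-c2nc3ccccc3[nH]2)c2nc(C#N)c(C#N)nc21`: > 50000 nM (a limit)
Compound 2 `CN1CCN(CCn2c(N)c(-c3nc4ccccc4[nH]3)c3nc(C#N)c(C#N)nc32)CC1`: 10900 nM
Compound 3 `CCCn1c(N)c(-c2nc3ccccc3[nH]2)c2nc(C#N)c(C#N)nc21`: > 50000 nM (a limit)

Compound 3 gives > 50000 nM in this assay, which is a limit and not a number. It stands at the limit of > 50000 nM in this assay, at which 2 of the 3 values shown sit, and compound 2 alone has a measured number.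

Compound 4 `CN1CCN(CCCn2c(N)c(-c3nc4ccccc4[nH]3)c3nc(C#N)c(C#N)nc32)CC1` differs from compound 3 by a single change: 4-methylpiperazin-1-yl in place of hydrogen on a saturated chain carbon, three bonds along the chain from an aromatic nitrogen. In other words, propyl becomes 3-(4-methylpiperazin-1-yl)propyl.

Going by the values given here, two measured steps bear on this change. The same group arrives on a shorter chain in an at least 4.5-fold lower number from compound 1 to compound 2 (0.66 log units; beyond the scatter). Its removal appears in an at least 4.5-fold higher number from compound 2 to compound 3 (0.66 log units; beyond the scatter). Chain length alone gives no guidance, as the data show a step that the two limits leave unreadable from compound 1 to compound 3. The closest guide is compound 2 at 10900 nM, which carries 2-(4-methylpiperazin-1-yl)ethyl. Among the compounds with values here, these are the only two readable steps, and both are limited by the assay on one side, so the expectation rests on little.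

A step of similar size towards a lower number is therefore expected. The expected step is an at least 4.5-fold lower number from compound 3 to compound 4 (0.65 log units; beyond the scatter). For compound 4 the estimated value is 11000 nM, with an expected range from 4000 nM to 30000 nM.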

Compound 4, half-maximal inhibitory concentration: 6260 nM
For compound 4 the middle estimate is 1.8-fold (0.24 log units) above the measured one; measured number inside the range.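

In this assay, the group on the longer chain gives an at least 7.9-fold lower number from compound 3 to compound 4 (0.90 log units; beyond the scatter), and measured against the methyl compound the same 3-(4-methylpiperazin-1-yl)propyl chain gives an at least 7.9-fold lower number from compound 1 to compound 4 (0.90 log units; beyond the scatter). Compound 1 and compound 3 each stand at a limit and not at a number, so both steps give only a minimum size: the limit of > 50000 nM in this assay, at which 2 of the 4 values shown sit. The new result shows that the shift to a measurable number is not confined to the 2-(4-methylpiperazin-1-yl)ethyl chain: among the four compounds, only those carrying the methylpiperazine have measured values, and nothing goes against this, while the change of chain length itself gives a 1.7-fold lower number from compound 2 to compound 4 (0.24 log units; within the scatter), so that the ethyl and propyl versions cannot be told apart in this read-out.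

The compounds shown leave open whether the methylpiperazine ring is needed at all, or whether a morpholine or a simple dimethylamine on the same propyl chain would give a similar number. They also leave open whether a longer chain, such as a butyl chain carrying the same ring, would stay level with compound 4 or move away from it.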